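The source may report more compounds than this note shows. Statements on the series, on what has been measured and on what is new or still open speak of the compounds shown alone.

Measured compounds:
compound 1, `Cn1c(CN2CCN(c3ccc(C(F)(F)F)cc3)CC2)nc2ccccc21`: 398 nM
compound 2, `Cn1c(CN2CCC(c3ccccc3)CC2)nc2ccccc21`: 100 nM

In a functional assay on HEK293 cells for antagonist activity at D(4) dopamine receptor (Homo sapiens), read by FLIPR (a lower number here means a stronger inhibitor, a higher number a weaker inhibitor), compound 2 gives 100 nM, the lowest of the two numbers, and compound 1 gives 398 nM, a gap beyond the usual scatter. Compound 3, `Cn1c(CN2CCC(c3ccc(Cl)cc3)CC2)nc2ccccc21`, is not yet measured. It differs from compound 2 by chloro in place of hydrogen on an aromatic carbon, on an aromatic carbon of a six-membered aromatic ring of carbon only. Among the compounds with values here, no measured pair shows this change, so its effect rests on no number. The step is expected to stay small, a 1.3-fold lower number from compound 2 to compound 3 (0.10 log units; within the scatter), within the scatter or just beyond it. Compound 3 is estimated at 80 nM, between 25 nM and 250 nM.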

Compound 3, inhibition constant: 63.1 nM
Beside the measured number, compound 3's estimate is 1.3-fold (0.10 log units) above it, within the range that was stated.
By their numbers in this assay, from the lowest: compounds 3 and 2 (each within the scatter of the next); then compound 1.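

In this assay, within the data shown here, the change from phenyl to 4-chlorophenyl gives a 1.6-fold lower number from compound 2 to compound 3 (0.20 log units; within the scatter), the first reading at this position. A chloro on this aromatic carbon, para to a large group, therefore leaves the number within the scatter of the unsubstituted compound, and no gain or loss can be claimed. Nothing available explains this outcome.

From the compounds shown here alone, whether a methoxy or a nitrile at this place would give a step beyond the scatter stays open. So does whether a hydroxyl or an amine there would be tolerated as the chloro is.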